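The source may report more compounds than this note shows. Statements on the series, on what has been measured and on what is new or still open speak of the compounds shown alone.

Working notes on the series. Of the compounds shown here, two have numbers so far: compound 1 `Cc1ccc(C(=O)Nc2cccc(CN3CCN(C)CC3)c2)cc1-c1ccc2cn[nH]c2c1` and compound 2 `Cc1ccc(C(=O)Nc2cccc(C(F)(F)F)c2)cc1-c1ccc2c(-c3cnn(C)c3)n[nH]c2c1`. In an assay on isolated protein for inhibition of Discoidin domain-containing receptor 2 (Homo sapiens), read by ELISA, with a stated time of 60 min (on this read-out lower numbers stand for stronger inhibition and higher numbers for weaker inhibition), compound 1 gives 75.9 nM, and in this assay compound 2 gives 4.4 nM. Compound 2 holds the lower of the two numbers, and its gap to compound 1 lies beyond the scatter, so compound 2 is the stronger of the two in this assay. The two differ in more than one place at once, so their gap cannot be tied to any single change.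

Compound 3 `Cc1ccc(C(=O)Nc2cccc(C(F)(F)F)c2)cc1-c1ccc2c(-c3cnn(C4CCOC4)c3)n[nH]c2c1` is not yet measured. It differs from compound 2 in one place: oxolan-3-yl in place of methyl on an aromatic nitrogen. Going by the values given here, no measured pair isolates a change of this kind, so there is nothing to calibrate against. The substituent on the pyrazole nitrogen sits away from the amide side of the molecule, and with no evidence either way the expectation is a step from compound 2 to compound 3 of a 1.1-fold higher number from compound 2 to compound 3 (0.06 log units; within the scatter), none beyond the scatter. Compound 3 is therefore estimated at 5 nM in this assay, within a range of 1.5 nM to 16 nM.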

Compound 3, half-maximal inhibitory concentration: 6.2 nM
Estimate against measurement, compound 3: 1.2-fold (0.09 log units) below, within the range that was stated.
By their numbers in this assay, from the lowest: compounds 2 and 3 (each within the scatter of the next); then compound 1.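

In this assay, going by these compounds alone, oxolan-3-yl in place of methyl on the aromatic nitrogen gives a 1.4-fold higher number from compound 2 to compound 3 (0.15 log units; within the scatter), the first step that isolates a single place. At this nitrogen, a methyl and a group bringing a five-membered non-aromatic ring and an oxygen therefore cannot be told apart on this read-out, and compound 3, at 6.2 nM, keeps the low-nanomolar level of compound 2, which the gap to compound 1 alone could not have shown for this position. Nothing on hand bears on why the two groups read alike.

The compounds shown leave open how far this latitude extends, since a single replacement at this nitrogen says nothing yet about a piperidine or another basic amine, a carboxylic acid, or a longer chain such as a methoxyethyl group. As far as these compounds go, it also remains open whether the same step would hold with the methylpiperazine-bearing amide side of compound 1 in place of the trifluoromethyl one.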